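The source may report more compounds than this note shows. Statements on the series, on what has been measured and on what is new or still open speak of the compounds shown alone.

Values in an ADME assay on GES1 cells (Homo sapiens) for inhibition, read by MTT assay, with a stated time of 72 h; a lower number here means a stronger inhibitor, a higher number a weaker inhibitor:
- compound 1 `Cc1cc(Nc2ccn(Cc3cccc4ccccc34)n2)n2nc(SCc3ccc(Br)cc3)nc2n1`: 30000 nM
- compound 2 `Cc1cc(Nc2cc(C(C)(C)C)[nH]n2)n2nc(SCc3ccc(Br)cc3)nc2n1`: > 50000 nM (a limit of the assay)
- compound 3 `C#CCSc1nc2nc(C)cc(Nc3cc(-c4ccccc4)[nH]n3)n2n1`: 45700 nM

Only two of these entries are numbers, and they lie within the scatter of each other, so compound 1 and compound 3 cannot be ranked. Compound 2 reaches a limit of this assay at > 50000 nM, and this is not a number.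

Compound 4 `Cc1cc(Nc2ccn(Cc3ccc(F)cc3)n2)n2nc(SCc3ccc(Br)cc3)nc2n1` keeps the core of compound 1 and changes one group: 4-fluorophenyl in place of naphthalen-1-yl on a saturated chain carbon bound to an aromatic nitrogen. This places 4-fluorophenyl in place of naphthalen-1-yl on a saturated chain carbon bound to an aromatic nitrogen.

Within the data shown here, no measured pair differs in one place, so no measured step guides this change. In this assay, no step beyond the scatter is expected, and so no direction is assigned. The estimated change is a 1.2-fold higher number from compound 1 to compound 4 (0.07 log units; within the scatter). For compound 4 the expected value is 35000 nM, with an estimated range of 15000 nM to 50000 nM.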

Compound 4, half-maximal inhibitory concentration: 40500 nM
The estimate for compound 4 lay 1.2-fold (0.06 log units) below the measured number; the measured number falls inside the stated range.
By their numbers in this assay, from the lowest: compounds 1, 4 and 3 (each within the scatter of the next). At a limit, above all of these: compound 2.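

In this assay, the series now holds its first step that can be read at a single position, a change confined to the group on a saturated chain carbon bound to an aromatic nitrogen: a 1.4-fold higher number from compound 1 to compound 4 (0.13 log units; within the scatter). On the core of compound 1, going from naphthalen-1-yl, with 2 six-membered aromatic rings, to 4-fluorophenyl, with one, therefore gives no step beyond the scatter, and this single pair cannot separate the loss of a ring from the entry of fluorine. Compound 2 remains a limit of the assay and not a number: the limit of > 50000 nM in this assay, at which 1 of the 4 values shown sits.

From the compounds shown here alone, whether an amine or a carboxylic acid in place of the aromatic ring at this position would give a step beyond the scatter stays open. Also open, going by these compounds, is whether a longer chain between the aromatic nitrogen and the ring would do so.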